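The source may report more compounds than this note shows. Statements on the series, on what has been measured and on what is new or still open speak of the compounds shown alone.

Working notes, an ADME assay on MT4 cells (Homo sapiens) for cytotoxicity, read by MTT assay; a lower number here means that less compound is tolerated, a higher number that more compound is tolerated:

- compound 1 `Cc1cc(C)cc(S(=O)(=O)c2c(C(=O)NNc3ccncc3)[nH]c3ccc(Cl)cc23)c1`: 30300 nM
- compound 2 `Cc1cc(C)cc(S(=O)(=O)c2c(C(=O)NCc3cccs3)[nH]c3ccc(Cl)cc23)c1`: 54500 nM

Compound 2 stands level with compound 1 on these two numbers, and no other measured neighbour exists. Next is compound 3 `Cc1cc(C)cc(S(=O)(=O)c2c(C(=O)NC(C)c3cccs3)[nH]c3ccc(Cl)cc23)c1`, which differs from compound 2 by methyl in place of hydrogen on a saturated chain carbon bound to an amide-type nitrogen and an aromatic carbon. For the measured compounds named here, no measured step covers this exact change. The nearest evidence is a 1.8-fold higher number from compound 1 to compound 2 (0.25 log units; within the scatter), where the whole group on the amide-type nitrogen was exchanged. Going by the values given here, with only that step to go on, no shift beyond the scatter is expected in this assay, and no direction can be argued. The expected step is a 1.1-fold lower number from compound 2 to compound 3 (0.06 log units; within the scatter). For compound 3 the estimated value is 48000 nM, with an expected range from 22000 nM to 95000 nM.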

Compound 3, half-maximal cytotoxic concentration: 32300 nM
Estimate against measurement, compound 3: 1.5-fold (0.17 log units) above, and the stated range covers the measured number.
By their numbers in this assay, from the lowest: compounds 1, 3 and 2 (each within the scatter of the next).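

Methyl in place of hydrogen on the saturated chain carbon bound to an amide-type nitrogen and an aromatic carbon gives the first direct reading at this position in this assay (a 1.7-fold lower number from compound 2 to compound 3 (0.23 log units; within the scatter)). Set against the (pyridin-4-yl)amino group, 1-(thiophen-2-yl)ethyl also stays within the scatter (a 1.1-fold higher number from compound 1 to compound 3 (0.03 log units; within the scatter)), so no step among the three groups on the amide-type nitrogen shown here separates them. Nothing measured bears on why these numbers stay so close.

As far as these compounds go, whether ethyl or a longer chain in place of that methyl, or an amine or a carboxylic acid on the same carbon, would move the number beyond the scatter remains open. From the compounds shown here alone, the shared core is the same in all three compounds, so the effect of replacing its chlorine with fluorine or methoxy also remains open.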